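The source may report more compounds than this note shows. Statements on the series, on what has been measured and on what is new or still open speak of the compounds shown alone.

Among the measured compounds shown here, in a functional assay on HUVEC cells (Homo sapiens) for inhibition, with stated times of 2 h and 72 h (on this read-out higher numbers stand for weaker inhibition and lower numbers for stronger inhibition), only two compounds on a shared core have been measured so far. Compound 1 (`COc1cc2nccc(Oc3ccc4c(NC(=O)Nc5ccc(C)cc5)nn(C)c4c3)c2cc1OC`) gives > 1000 nM and this is a limit of the assay, not a number. Compound 2 (`COc1cc2nccc(Oc3ccc4c(Nc5ccccc5)nn(C)c4c3)c2cc1OC`) gives > 1000 nM and this too is only a limit. Compound 2 therefore has no number of its own and stands with compound 1 at the same point (the limit of > 1000 nM in this assay, at which 2 of the 2 values shown sit).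

Compound 3 (`COc1cc2nccc(Oc3ccc4c(NC(=O)c5ccc(C(F)(F)F)cc5)nn(C)c4c3)c2cc1OC`) differs from compound 2 in one place ((4-(trifluoromethyl)phenyl)carbonyl in place of phenyl on a nitrogen on an aromatic ring), with (4-(trifluoromethyl)phenyl)carbonyl in place of phenyl on a nitrogen on an aromatic ring. As in compound 1, a carbonyl then sits on that nitrogen.

For the measured compounds named here, the only measured step that bears on this change (a step that the two limits leave unreadable from compound 1 to compound 2) has no readable size, so it offers nothing to carry over to the new group. The estimated step (a step that the limit leaves unreadable from compound 2 to compound 3) is expected to have no clear direction in this assay and compound 3 is expected to remain weak. Compound 3 is estimated at 1500 nM with an expected range from 300 nM to 6000 nM and a good chance that the outcome is only a limit.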

Compound 3, half-maximal inhibitory concentration: > 1000 nM
Compound 3 was reported as a limit; the forecaster's own chance of this, stated with the estimate: 70%; the middle value does not contradict the limit.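

In this assay compound 3 gives > 1000 nM, which is a limit and not a number. Among the compounds shown here, no step among compound 1, compound 2 and compound 3 can be read, as all three values are limits: the limit of > 1000 nM in this assay, at which 3 of the 3 values shown sit. The compounds shown leave open how strongly any of the three inhibits and whether the groups on that nitrogen differ at all.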